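This account rests on a few compounds, and the source may have more. Where it says the series, first, only, none or still open, it means among the compounds named here.

Among the measured compounds shown here, in a functional assay on HeLa cells (Homo sapiens) for cytotoxicity, read by MTT assay, with a stated time of 48 h (a lower number here means a stronger inhibitor, a higher number a weaker inhibitor), two compounds on a shared core have numbers so far. Compound 1 `O=C(/C=C\Nc1ccccc1)c1ccc2c(c1)CCCC2` gives 30.6 ug/mL and compound 2 `O=C(/C=C\Nc1ccc(Cl)cc1)c1ccc2c(c1)CCCC2` gives 19.9 ug/mL on the same read-out. Compound 2 therefore stands within the scatter of compound 1, and the pair cannot be told apart. Compound 3 `Cc1ccc(N/C=C\C(=O)c2ccc3c(c2)CCCC3)cc1` has not yet been measured. It departs from compound 2 by a single exchange, (methyl in place of chloro on an aromatic carbon), which is methyl in place of chloro on an aromatic carbon, para to a large group. For the measured compounds named here, only one measured step bears on this position. Chloro in place of hydrogen on that same aromatic carbon gave a 1.5-fold lower number from compound 1 to compound 2 (0.19 log units; within the scatter) as the sole guide. Going by the values given here, no methyl compound has been measured on this core, so nothing supports a large move. The expected step is a 1.3-fold higher number from compound 2 to compound 3 (0.10 log units; within the scatter) in this assay, which means a slightly higher number and no change beyond the scatter. For compound 3 the estimated value is 25 ug/mL with an expected range from 13 ug/mL to 45 ug/mL on this reasoning.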

Compound 3, half-maximal inhibitory concentration: 28.7 ug/mL
Beside the measured number, compound 3's estimate is 1.1-fold (0.06 log units) below it; low and high end bracket the measured number.
By their numbers in this assay, from the lowest: compounds 2, 3 and 1 (each within the scatter of the next).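

In this assay, the exchange of 4-chlorophenyl for 4-methylphenyl gives a 1.4-fold higher number from compound 2 to compound 3 (0.16 log units; within the scatter), while methyl in place of hydrogen on the same aromatic carbon gives a 1.1-fold lower number from compound 1 to compound 3 (0.03 log units; within the scatter). The earlier compounds shown here offered only one replacement of hydrogen at this position, chloro; there is now a second, methyl, and it too leaves the number within the scatter. Across compound 1, compound 2 and compound 3, hydrogen, chloro and methyl on this aromatic carbon, para to a large group, therefore cannot be told apart on this read-out, and no measured property of these groups is available to explain that result.

As far as these compounds go, what remains open is whether a group of another kind at this position, such as an amine, a carboxylic acid or a longer chain, would produce a step beyond the scatter. The three compounds also leave open whether changes elsewhere on the shared core would matter more than this position does, since all of them differ only on this one aromatic carbon.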